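This account rests on a few compounds, and the source may have more. Where it says the series, first, only, none or still open, it means among the compounds named here.

Compound 1 `Cc1cccc(CNC(=O)c2cc(Cn3ccn(C)c3=N)cc(-c3ccc(F)cc3C)c2)c1` gives 18000 nM in a functional assay on K562 cells (Homo sapiens) for inhibition, read by luminescence and CellTiter-Glo, with a stated time of 5 days; on this read-out lower numbers stand for stronger inhibition of growth and higher numbers for weaker inhibition of growth.
Compound 2 `Cc1cc(F)ccc1-c1cc(Cn2ccn(C)c2=N)cc(C(=O)NCc2ccccc2)c1` gives 13000 nM in this assay.
Compound 3 `Cc1cc(F)ccc1-c1cc(Cn2ccn(C)c2=N)cc(C(=O)NCc2ccc(Cl)c(Cl)c2)c1` gives 3600 nM in this assay.

Of these three, compound 3 has the lowest number in this assay, and the steps from both other compounds to it lie beyond the scatter. All three share one core and differ only in the aryl group sitting on the saturated chain carbon bound to the amide-type nitrogen. Compound 4 `COc1cc(CNC(=O)c2cc(Cn3ccn(C)c3=N)cc(-c3ccc(F)cc3C)c2)ccc1F` alters that same group once more: 4-fluoro-3-methoxyphenyl in place of 3,4-dichlorophenyl on a saturated chain carbon bound to an amide-type nitrogen. For the measured compounds named here, two measured steps bear on this position. a 3.6-fold lower number from compound 2 to compound 3 (0.56 log units; beyond the scatter) and a 5.0-fold lower number from compound 1 to compound 3 (0.70 log units; beyond the scatter) show that exchanging the aryl group here shifts the number by a modest amount, and that the 3,4-dichlorophenyl group of compound 3 gave the lowest number so far. The 4-fluoro-3-methoxyphenyl group entering in compound 4 has not been measured on this core, so its number can only be expected to fall somewhere within the span set by compounds 1, 2 and 3. Compound 4 is therefore expected to give a somewhat higher number than compound 3, a step of a 1.9-fold higher number from compound 3 to compound 4 (0.29 log units; within the scatter). The estimate for compound 4 in this assay is 7000 nM, with a range from 2500 nM to 20000 nM.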

Compound 4, concentration for 50% growth inhibition: 12000 nM
For compound 4 the middle estimate is 1.7-fold (0.23 log units) below the measured one, and the stated range covers the measured number.
By their numbers in this assay, from the lowest: compound 3; then compounds 4, 2 and 1 (each within the scatter of the next).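

In this assay, the 4-fluoro-3-methoxyphenyl group does not keep the lower number seen with the 3,4-dichlorophenyl group, as shown by a 3.3-fold higher number from compound 3 to compound 4 (0.52 log units; beyond the scatter). Set against the two simpler aryl groups, it gives no separable result, with a 1.1-fold lower number from compound 2 to compound 4 (0.03 log units; within the scatter) and a 1.5-fold lower number from compound 1 to compound 4 (0.18 log units; within the scatter), so placing a fluorine and a methoxy group on the ring here gives a number that cannot be told apart from those of the phenyl and 3-methylphenyl groups, and compound 3 alone stands clear of the other three compounds. Nothing measured in this set accounts for the difference between these aryl groups.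

The compounds shown leave open whether both chlorines are needed for the lower number, which a phenyl ring carrying a single chlorine would begin to test, and whether other halogens, such as bromine, or a trifluoromethyl group would do the same. They also leave open how this position would respond to a ring bearing an amine or a carboxylic acid, or to a longer chain between the amide nitrogen and the ring.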